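Swapping difluoromethyl for hydroxy on a shared core

The source may hold more compounds than are shown below. What is called first, only, known or untested is meant among the compounds shown, and "the series" means these compounds.

Values in a physicochemical assay for lipophilicity, using the shake flask method (a lower number here means a more polar compound, a higher number a more lipophilic compound), so far are these
- Compound 1 `Cc1cc(O[C@@H](C)c2c(Cl)ccc(F)c2Cl)ccc1/C=C/C(=O)O` gives 3.2
- Compound 2 `C[C@H](Oc1ccc2ncc(/C=C/C(=O)O)c(C3CC3)c2c1)c1c(Cl)ccc(N)c1Cl` gives 2.8
- Compound 3 `C[C@H](Oc1ccc2ncc(/C=C/C(=O)O)c(C(F)F)c2c1)c1c(Cl)ccc(F)c1Cl` gives 3.1

Compound 3 at 3.1 lies within the usual scatter of both compound 1 and compound 2, so it cannot be ranked against either one. Compound 4 `C[C@H](Oc1ccc2ncc(/C=C/C(=O)O)c(O)c2c1)c1c(Cl)ccc(F)c1Cl` differs from compound 3 in one place, with hydroxy in place of difluoromethyl on an aromatic carbon opposite the ring nitrogen. Among the compounds with values here, no measured pair shows this swap, so the expectation rests on the structural change alone. A downward move beyond the scatter is expected, estimated as a number 1.20 log units lower from compound 3 to compound 4 (beyond the scatter) in this assay readings. Compound 4 is expected at 1.9 with an estimated range from 1.3 to 2.6 in this assay readings.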

Compound 4, distribution coefficient: 1.9
The estimate for compound 4 equals the measured number at the digits printed, within the range that was stated.
By their numbers in this assay, from the lowest: compound 4; then compounds 2, 3 and 1 (each within the scatter of the next, the first and the last beyond it).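

Within the data shown here, this pair gives the first direct reading at this position, the aromatic carbon opposite the ring nitrogen, where in this assay hydroxy in place of difluoromethyl gives a number 1.20 log units lower from compound 3 to compound 4 (beyond the scatter), a large step beyond the scatter. Hydroxy brings one hydrogen-bond donor and difluoromethyl has none, but no measurement here explains the size of the step. As far as these compounds go, whether an amine or a methoxy group at this carbon would read closer to compound 3 or compound 4 remains open, as does whether this swap moves the number as far on another core.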